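The source may report more compounds than this note shows. Statements on the series, on what has been measured and on what is new or still open speak of the compounds shown alone.

Compound 2 `COc1cc(/C=C2\CCC/C(=C\c3cccc(O)c3)C2=O)cc(OC)c1OC` and compound 1 `COc1cc(/C=C2\CCC/C(=C\c3ccccc3F)C2=O)cc(OC)c1OC` share one core and differ only in the ring that sits on a double-bonded chain carbon bound to a double-bonded ring carbon. Among the compounds with values here, in a functional assay on LoVo cells (Homo sapiens) for antiproliferative activity, read by MTT assay, with a stated time of 72 h (on this read-out lower numbers stand for stronger inhibition and higher numbers for weaker inhibition), compound 1 gives 1900 nM, and compound 2 gives 4800 nM, the higher of the two numbers measured so far. The step of a 2.5-fold higher number from compound 1 to compound 2 (0.40 log units; beyond the scatter) lies beyond the scatter and is modest, so compound 2 is the weaker inhibitor of the pair. Compound 3 `COc1cc(/C=C2\CCC/C(=C\c3ccc(O)c(Cl)c3)C2=O)cc(OC)c1OC` has not yet been tested; it differs from compound 2 by 3-chloro-4-hydroxyphenyl in place of 3-hydroxyphenyl on a double-bonded chain carbon bound to a double-bonded ring carbon. Within the data shown here, only one measured step, a 2.5-fold higher number from compound 1 to compound 2 (0.40 log units; beyond the scatter), touches this same place, and it exchanged a different pair of groups, so it shows that changing this ring can shift the number modestly but gives no clear direction for the present exchange. The step from compound 2 to compound 3 is therefore expected to be small, a 1.4-fold lower number from compound 2 to compound 3 (0.14 log units; within the scatter), with no confident direction. Compound 3 is estimated at 3500 nM, within a range from 1400 nM to 9000 nM.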

Compound 3, half-maximal inhibitory concentration: 1100 nM
Compound 3: middle estimate off by 3.2-fold (0.50 log units), on the high side; the whole stated range lies above it.
By their numbers in this assay, from the lowest: compounds 3 and 1 (each within the scatter of the next); then compound 2.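

In this assay, placing 3-chloro-4-hydroxyphenyl in place of 3-hydroxyphenyl on a double-bonded chain carbon bound to a double-bonded ring carbon gives a 4.4-fold lower number from compound 2 to compound 3 (0.64 log units; beyond the scatter), which shows that a ring carrying a hydroxy group at this position can match the fluorinated ring of compound 1. That match is seen in a 1.7-fold lower number from compound 1 to compound 3 (0.24 log units; within the scatter), so compound 1 and compound 3 cannot be told apart here, even though their rings share no substituent. The data shown offer no measurement that explains the step from compound 2 to compound 3.

As far as these compounds go, the new ring differs from the old one in two ways at once, as 3-chloro-4-hydroxyphenyl has a chloro group that 3-hydroxyphenyl lacks and the two names place the hydroxy group differently, so the share of each change remains open; 3-chlorophenyl and 4-hydroxyphenyl rings at this place would separate them. From the compounds shown here alone, how this position responds to very different groups, such as a ring bearing an amine or a carboxylic acid, also remains open.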